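The source may hold more compounds than are shown below. What is called first, only, known or untested is meant among the compounds shown, and "the series" means these compounds.

Measured so far:
compound 1 `COc1cc2nc(N3CCN(S(=O)(=O)c4cccc(C(=O)O)c4)CC3)nc(N)c2cc1OC` gives 53000 nM
compound 2 `COc1cc2nc(N3CCN(S(=O)(=O)c4cc(F)c(Cl)c(C(=O)O)c4)CC3)nc(N)c2cc1OC` gives 56000 nM

Going by the values given here, in a functional assay on PC-3 cells (Homo sapiens) for inhibition (on this read-out lower numbers stand for stronger inhibition and higher numbers for weaker inhibition), compound 2 stands as the higher of the two numbers, with compound 1 nearest, and the one measured step, a 1.1-fold higher number from compound 1 to compound 2 (0.02 log units; within the scatter), shows that the two compounds are not separated beyond the scatter. Compound 3 `COc1cc2nc(N3CCN(S(=O)(=O)c4ccc5ccccc5c4)CC3)nc(N)c2cc1OC` has not yet been measured. It differs from compound 2 by naphthalen-2-yl in place of 3-carboxy-4-chloro-5-fluorophenyl on a sulfonyl sulfur, so that the acid-bearing ring is exchanged for a second fused ring. Among the compounds with values here, only one measured step exists, and it concerns a change on the same ring, leaving the carboxylic acid in place; it was small, so it gives no sign that this ring responds strongly to change. Within the data shown here, no measured pair removes the acid. Compound 3 is therefore expected to give 50000 nM in this assay, within a range from 12000 nM to 200000 nM. The step from compound 2 is expected to be about a 1.1-fold lower number from compound 2 to compound 3 (0.05 log units; within the scatter), which is no more than the scatter, though the range is kept wide.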

Compound 3, half-maximal inhibitory concentration: 15000 nM
Compound 3: the middle estimate sits 3.3-fold (0.52 log units) above what was measured; the measured number falls inside the stated range.
By their numbers in this assay, from the lowest: compound 3; then compounds 1 and 2 (each within the scatter of the next).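

In this assay, the substituent on the sulfonyl sulfur turns out to matter: naphthalen-2-yl in place of 3-carboxy-4-chloro-5-fluorophenyl gives a 3.7-fold lower number from compound 2 to compound 3 (0.57 log units; beyond the scatter) and in place of 3-carboxyphenyl gives a 3.5-fold lower number from compound 1 to compound 3 (0.55 log units; beyond the scatter) with both steps modest but beyond the scatter. Compound 1 and compound 2 had stayed within the scatter of each other, so exchanging the chlorine and fluorine substituents alone had shown no response, whereas replacing the whole acid-bearing ring does move the number. Nothing available explains this shift.

The removal of the carboxylic acid and the addition of a second fused ring are joined in this change, so the compounds shown leave open which of them accounts for the step. A plain phenyl on the sulfonyl sulfur, or a naphthalen-2-yl carrying a carboxylic acid, would separate the two.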